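A few compounds are considered here, and "the series" means these few. Any claim that something is new, unique, unknown or untested is made for them only; others in the source may bear on it.

Compound 3 `O=C(NS(=O)(=O)CCNC(=O)C1CC1)c1ccc(Nc2nc(NC3(c4ccc(Cl)cc4)CC3)nc(OCC(F)(F)F)n2)cc1` is the compound with the smallest number of the three in an ADME assay on microsomes from liver (Homo sapiens) for metabolic stability, with a stated time of 10 min; on this read-out lower numbers stand for a less stable compound and higher numbers for a more stable compound; compound 3 gives 90%. The two others lie within the scatter of it: compound 1 `CC(C)(C)NC(=O)NCCS(=O)(=O)NC(=O)c1ccc(Nc2nc(NC3(c4ccc(Cl)cc4)CC3)nc(OCC(F)(F)F)n2)cc1` gives 96%, and compound 2 `CCS(=O)(=O)NC(=O)c1ccc(Nc2nc(NC3(c4ccc(Cl)cc4)CC3)nc(OCC(F)(F)F)n2)cc1` gives 100%. Compound 4 `CC(C)(C)CNCCS(=O)(=O)NC(=O)c1ccc(Nc2nc(NC3(c4ccc(Cl)cc4)CC3)nc(OCC(F)(F)F)n2)cc1` has not yet been measured in this assay. Its structure differs from compound 3 by neopentyl in place of cyclopropylcarbonyl on an amine nitrogen. The measured steps touch the same side chain without repeating this change. Adding the (cyclopropylcarbonyl)amino group to the chain reads a number 10 percentage points lower from compound 2 to compound 3 (within the scatter), exchanging the (tert-butyl)amino group for cyclopropyl on the carbonyl carbon reads a number 6 percentage points lower from compound 1 to compound 3 (within the scatter), and removing the whole urea reads a number 4 percentage points higher from compound 1 to compound 2 (within the scatter); all three are within the scatter. Within the data shown here, no measured compound carries a basic amine on this chain, so the effect of the neopentylamino group is not known from the data. Since every variation of this chain so far has stayed within the scatter, compound 4 is expected to remain near compound 3, with an estimated step of a number 2 percentage points lower from compound 3 to compound 4 (within the scatter) in this assay. The estimate for compound 4 in this assay is therefore 88%, with a range from 70% to 100%.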

Compound 4, percent of the compound remaining: 89%
Compound 4: middle estimate off by 1 percentage points, on the low side; low and high end bracket the measured number.
By their numbers in this assay, from the lowest: compounds 4, 3, 1 and 2 (each within the scatter of the next, the first and the last beyond it).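

In this assay, neopentyl in place of cyclopropylcarbonyl on the amine nitrogen reads a number 1 percentage points lower from compound 3 to compound 4 (within the scatter), so at an equal count of heavy atoms, and without the carbonyl or the three-membered ring, this read-out does not separate the amine of compound 4 from the amide of compound 3. Neopentyl in place of (tert-butyl)carbamoyl on the same nitrogen likewise reads a number 7 percentage points lower from compound 1 to compound 4 (within the scatter), whereas neopentylamino in place of hydrogen on the saturated chain carbon reads a number 11 percentage points lower from compound 2 to compound 4 (beyond the scatter), the only step among these compounds that passes the scatter, and a modest one. No measurement among the data given accounts for these numbers.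

The compounds shown leave open how this assay would read with a tertiary amine, a carboxylic acid or a longer chain on this side chain, and so whether the step from compound 2 holds for other groups on the nitrogen. They also leave open whether the compounds would separate more clearly over a longer incubation, as all four stand close together at this single stated time.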